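The source may report more compounds than this note shows. Statements on the series, on what has been measured and on what is new or still open speak of the compounds shown alone.

In an ADME assay on MDCK cells (Canis lupus familiaris) for permeability, in the apical to basolateral direction (on this read-out lower numbers stand for lower permeability and higher numbers for higher permeability), compound 2, `CC(C)[C@@H](c1ccc(-c2ccc3cccc(F)c3c2)[nH]c1=O)[C@H]1OC(=O)NC1=O`, gives 9.14 10^-6 cm/s. Compound 1, `CC(C)[C@H](C[C@H]1OC(=O)NC1=O)c1ccc(-c2ccc3cccc(F)c3c2)[nH]c1=O`, gives 10.3 10^-6 cm/s, and compound 3, `CC(C)C(c1ccc(-c2ccc3cccc(F)c3c2)[nH]c1=O)C1SC(=O)NC1=O`, gives 26.3 10^-6 cm/s; the numbers of compound 2 and compound 3 thus lie clearly apart, while those of compound 2 and compound 1 do not. For the measured compounds named here, the one measured step, a 1.1-fold lower number from compound 1 to compound 2 (0.05 log units; within the scatter), concerns the removal of a chain carbon rather than configuration.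

Compound 4, `CC(C)[C@@H](c1ccc(-c2ccc3cccc(F)c3c2)[nH]c1=O)[C@@H]1OC(=O)NC1=O`, differs from compound 2 as follows: the two compounds have the same atoms and bonds and differ only in configuration as drawn: 1 of 2 stereo elements differ; a stereocentre at a saturated ring carbon is drawn R in compound 2 and S in compound 4. Going by the values given here, no measured pair among compound 1, compound 2 and compound 3 differs only in the configuration of this stereocentre, so no measured step bears directly on this change. With the same atoms and bonds retained, compound 4 is expected to sit close to compound 2, so the step of a 1.0-fold higher number from compound 2 to compound 4 (0.02 log units; within the scatter) is estimated to stay within the scatter. The estimate for compound 4 is therefore 9.5 10^-6 cm/s, within a range from 4.5 10^-6 cm/s to 20 10^-6 cm/s.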

Compound 4, apparent permeability: 3.15 10^-6 cm/s
For compound 4 the middle estimate is 3.0-fold (0.48 log units) above the measured one, outside the stated range (below it).
By their numbers in this assay, from the lowest: compound 4; then compounds 2 and 1 (each within the scatter of the next); then compound 3.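

In this assay, the configuration of the saturated ring carbon proves not to be a silent feature, since drawing it S rather than R goes with a 2.9-fold lower number from compound 2 to compound 4 (0.46 log units; beyond the scatter), and nothing else can account for that step: the fact that compounds 2 and 4 differ only in the configuration as drawn

The removal of the chain carbon also reads differently with this configuration: a 1.1-fold lower number from compound 1 to compound 2 (0.05 log units; within the scatter), whereas a 3.3-fold lower number from compound 1 to compound 4 (0.51 log units; beyond the scatter). Among these compounds, then, the outcome of shortening the chain depends on how the ring carbon is drawn.

From the compounds shown here alone, it remains open whether the configuration of the saturated chain carbon, which compound 2 and compound 4 share, counts as much as that of the ring carbon. Also open, going by these compounds, is how this read-out would respond to an amine or a carboxylic acid in place of the 2,4-dioxo-1,3-oxazolidin-5-yl group.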